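The source may report more compounds than this note shows. Statements on the series, on what has been measured and on what is new or still open speak of the compounds shown alone.

Of the compounds shown here, three have been measured in an assay on isolated protein for inhibition of tyrosine-protein kinase Mer (Homo sapiens), read by LC-MS, with stated times of 30 min and 120 min; a higher number here means a weaker inhibitor, a lower number a stronger inhibitor. Compound 1 `COc1cc2c(Nc3cnc(OCCCC4CCCC4)nc3)ncnc2cc1OCCCN1CCCCC1` gives 0.794 nM, compound 2 `CNC(=O)c1cnc(Nc2ccc(OC)cc2C)nc1NC1CCCC1` gives 794 nM, and compound 3 `CNC(=O)c1sc(N2CC3CC2(CNC(=O)c2c[nH]c4ncc(C(F)(F)F)cc24)C3)nc1C(F)(F)F` gives 63.1 nM. Compound 3 thus holds the second highest number of the three: compound 2 sits above it by a gap beyond the scatter, and compound 1 sits well below it, also beyond the scatter. Compound 4 `CNC(=O)c1sc(N2CC3CC2(CNC(=O)c2c[nH]c4ncccc24)C3)nc1C(F)(F)F` differs from compound 3 in one place: hydrogen in place of trifluoromethyl on an aromatic carbon. Among the compounds with values here, no measured pair shows this change, so its effect is not known from the data. The step from compound 3 to compound 4 is estimated as a 2.5-fold higher number from compound 3 to compound 4 (0.40 log units; beyond the scatter), a modest move toward a weaker inhibitor. Compound 4 is therefore expected to give about 160 nM, within a range from 40 nM to 630 nM.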

Compound 4, half-maximal inhibitory concentration: 25.1 nM
For compound 4 the middle estimate is 6.4-fold (0.80 log units) above the measured one; the whole stated range lies above it.
By their numbers in this assay, from the lowest: compound 1; then compound 4; then compound 3; then compound 2.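

Replacing trifluoromethyl with hydrogen on this aromatic carbon gives a 2.5-fold lower number from compound 3 to compound 4 (0.40 log units; beyond the scatter) in this assay, a modest gain in strength that lies beyond the scatter. In this pair, then, the inhibitor does not need trifluoromethyl at this position, and the carbon carrying only hydrogen does better. Nothing available explains this shift. From the compounds shown here alone, whether fluorine, chlorine or a methyl group on the same carbon would give a lower or higher number remains open. So does whether this change would have the same effect on another core.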